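This account rests on a few compounds, and the source may have more. Where it says the series, first, only, none or still open, it means among the compounds named here.

Working notes on the series. Compound 2 `COc1cccc2sc(NC(=O)c3ccc([N+](=O)[O-])cc3)nc12` and compound 1 `COc1cccc2sc(NC(=O)c3ccc(C(F)(F)F)cc3)nc12` share one core; compound 3 `Cc1cc(C)c2sc(NC(=O)c3ccc([N+](=O)[O-])cc3)nc2c1` and the still unmeasured compound 4 `Cc1cc(C)c2sc(NC(=O)c3ccc(C(F)(F)F)cc3)nc2c1` share another, and the difference between the two cores is not broken down here. In a functional assay on MDA-MB-231 cells (Homo sapiens) for antiproliferative activity, read by sulforhodamine B assay (a lower number here means a stronger inhibitor of growth, a higher number a weaker inhibitor of growth), compound 2 gives > 10 ug/mL, which is a limit of the assay and not a number. In this assay compound 1 likewise gives > 10 ug/mL, again a limit. The change trifluoromethyl in place of nitro on an aromatic carbon thus makes a step that the two limits leave unreadable from compound 2 to compound 1, unreadable because the limit of > 10 ug/mL in this assay, at which 2 of the 3 values shown sit, holds both ends. In this assay, for the measured compounds named here, compound 3 gives 0.29 ug/mL, the only numerical reading among the three. The change trifluoromethyl in place of nitro on an aromatic carbon is the same change as from compound 2 to compound 1, at the same place. The step of a 3.1-fold higher number from compound 3 to compound 4 (0.49 log units; beyond the scatter) is expected to be modest, since the earlier step that the two limits leave unreadable from compound 2 to compound 1 gives no readable size to copy. Compound 4 is therefore estimated at 0.9 ug/mL, within 0.3 ug/mL to 4 ug/mL.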

Compound 4, concentration for 50% growth inhibition: 0.45 ug/mL
Compound 4: the middle estimate sits 2.0-fold (0.30 log units) above what was measured; low and high end bracket the measured number.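

In this assay the step on the core of compound 3 is a 1.6-fold higher number from compound 3 to compound 4 (0.19 log units; within the scatter), so on this core trifluoromethyl and nitro on this aromatic carbon cannot be told apart. From compound 2 to compound 1 the same change cannot be read, since both values are limits of the assay and not numbers: the limit of > 10 ug/mL in this assay, at which 2 of the 4 values shown sit. One readable pair therefore does not show that the change carries from one core to the other; it shows only its outcome on the core of compound 3.

Open, on these data alone, is how an amine or a carboxylic acid on the same aromatic carbon would fare on either core. Also open, as far as these compounds go, is which part of the difference between the two cores matters in this assay.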